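This account rests on a few compounds, and the source may have more. Where it says the series, first, only, none or still open, it means among the compounds named here.

Measured compounds:
compound 1, `CC(C)=CCC/C(C)=C/CC1Cc2c(OCCCNS(=O)(=O)c3ccc(Cl)cc3)cc(=O)n(CCCO)c2CC1(C)C`, 16.1%
compound 2, `CC(C)=CCC/C(C)=C/CC1Cc2c(OCCCNS(=O)(=O)c3ccc([N+](=O)[O-])cc3)cc(=O)n(CCCO)c2CC1(C)C`, 0%
compound 3, `CC(C)=CCC/C(C)=C/CC1Cc2c(OCCCOc3ccc(Cl)cc3)cc(=O)n(CCCO)c2CC1(C)C`, 0%

All three were tested in a functional assay on PANC-1 cells (Homo sapiens) for inhibition, read by MTT assay, with a stated time of 24 h, tested at 10 uM; on this read-out higher numbers stand for more inhibition at the one concentration tested (going by the name of the read-out) and lower numbers for less inhibition. Compound 1 is the only one of the three to show a read-out above zero; in this assay compound 1 gives 16.1%. The change nitro in place of chloro on an aromatic carbon gave a number 16.1 percentage points lower from compound 1 to compound 2 (beyond the scatter), so that compound 2 shows 0%. A different change, (4-chlorophenoxy in place of ((4-chlorophenyl)sulfonyl)amino on a saturated chain carbon, three bonds along the chain from an oxygen on an aromatic ring), gave a number 16.1 percentage points lower from compound 1 to compound 3 (beyond the scatter); compound 3 thus shows 0%, level with compound 2 at the digits reported, and the two stand together at the lowest value of the set.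

Compound 4, `CC(C)=CCC/C(C)=C/CC1Cc2c(OCCCOc3ccc([N+](=O)[O-])cc3)cc(=O)n(CCCO)c2CC1(C)C`, is not yet measured. It differs from compound 3 by nitro in place of chloro on an aromatic carbon. Among the compounds with values here, this is the same change as the one from compound 1 to compound 2, and the place where it is made is described in the same words in both cases; the two cores, however, differ as told by 4-chlorophenoxy in place of ((4-chlorophenyl)sulfonyl)amino on a saturated chain carbon, three bonds along the chain from an oxygen on an aromatic ring. The earlier step was a modest fall. Here the starting point, compound 3, is already at zero inhibition, so a fall of the same size cannot be expressed on this read-out, and no rise is suggested by anything in the set. Compound 4 is therefore expected to stay at the bottom of the read-out, with an estimated step of no change at the digits printed from compound 3 to compound 4 (within the scatter). The estimate for compound 4 in this assay is 0%, between 0% and 9%.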

Compound 4, a percentage reported as inhibition, at one concentration (the size of the read-out at that concentration, not a potency): 9.8%
The estimate for compound 4 lay 9.8 percentage points below the measured number; the measured number lies above the stated range.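

On the core of compound 3, nitro in place of chloro on an aromatic carbon gave a number 9.8 percentage points higher from compound 3 to compound 4 (within the scatter), and the step that exchanges the whole side group gave a number 6.3 percentage points lower from compound 1 to compound 4 (within the scatter). The exchange of chloro for nitro therefore did not carry over from one core to the other in this assay, and the fall seen on the core of compound 1 cannot be assumed on the core of compound 3: the same change on two cores in this assay, a number 16.1 percentage points lower (beyond the scatter) from compound 1 to compound 2 and a number 9.8 percentage points higher (within the scatter) from compound 3 to compound 4, 25.9 percentage points apart, beyond the scatter of two such steps. This does not show that nitro raises inhibition on the core of compound 3, since that step lies within the scatter, and with a single pair on each core, all at one concentration, it gives no general rule for the series and no reason for the difference between the two cores.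

The compounds shown leave open whether a methoxy or a trifluoromethyl group in place of chloro on the same aromatic carbon would also behave differently on the two cores. They also leave open whether the difference would persist with an amide in place of the sulfonamide link, or with a longer chain between the ring oxygen and the terminal aromatic ring.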